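The compounds below may be only part of what the source reports. "The series", "measured", "known", "first", "only" and "open" are said of these compounds alone.

Of the compounds shown here, three have been measured in an assay on isolated protein for inhibition of tyrosine-protein kinase receptor UFO (Homo sapiens), with a stated time of 1.5 h; on this read-out lower numbers stand for stronger inhibition and higher numbers for weaker inhibition. Compound 1 `N#Cc1ccc(-n2cc(-c3n[nH]c4cc(Cl)c(N[C@@H]5CCNC5)cc34)cn2)cc1` gives 700 nM in this assay, the lowest of the three numbers. Compound 3 `Cn1cc(-c2n[nH]c3cc(N)ccc23)cn1` gives 28800 nM in this assay, and compound 2 `Cn1cc(-c2n[nH]c3ccc(N[C@H]4CCNC4)cc23)cn1` gives 239000 nM in this assay. Both of these stand beyond the usual scatter from compound 1, with compound 3 the nearer and compound 2 the furthest away. Going by the values given here, no pair of these measured compounds differs in a single place, so their values can only be taken as they stand, without a step between them.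

Compound 4 `Fc1ccc(-n2cc(-c3n[nH]c4cc(Cl)c(N[C@@H]5CCNC5)cc34)cn2)cc1` has not yet been measured. It differs from compound 1 by fluoro in place of cyano on an aromatic carbon, a change that, read one bond further out, turns a 4-cyanophenyl into a 4-fluorophenyl, sitting para to a large group on a six-membered aromatic ring of carbon only. Among the compounds with values here, no measured step offers a guide to the size of this change. The step of a 1.7-fold higher number from compound 1 to compound 4 (0.23 log units; within the scatter) in this assay is expected to be small, at most a little beyond the scatter and toward a higher number. Compound 4 is therefore estimated to give about 1200 nM in this assay, with a range from 400 nM to 4000 nM.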

Compound 4, half-maximal inhibitory concentration: 2300 nM
Compound 4: the middle estimate sits 1.9-fold (0.28 log units) below what was measured; the range from low to high includes it.
By their numbers in this assay, from the lowest: compound 1; then compound 4; then compound 3; then compound 2.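

In this assay, replacing the nitrile with fluoro gives a 3.3-fold higher number from compound 1 to compound 4 (0.52 log units; beyond the scatter), a modest step but one beyond the usual scatter. Going by these compounds alone, this is the first comparison here in which only one place changes, and it shows that the number responds to the group on this aromatic carbon, with the 4-cyanophenyl giving the lower number of the two. Nothing available here explains the rise, so the step stands as an observation without a cause.

From the compounds shown here alone, whether a methoxy group, an amine or a carboxylic acid in this same place would give a lower or higher number than the nitrile remains open. The contribution of the chloro group on the shared core is also unresolved, as no pair shown differs by that group alone.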